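The source may hold more compounds than are shown below. What is called first, only, known or untested is meant among the compounds shown, and "the series" means these compounds.

Compound 3 `CS(=O)(=O)c1ccc(F)cc1NCC1=NCCN1` carries a methylsulfonyl group and a fluoro on the shared core. In a functional assay for agonist activity at Alpha-1B adrenergic receptor (Homo sapiens) (on this read-out lower numbers stand for an effect already at smaller amounts and higher numbers for an effect only at larger amounts of compound), compound 3 gives < 100000 nM, which is a limit of the assay rather than a number. Compound 1 `COc1ccc(S(C)(=O)=O)c(NCC2=NCCN2)c1` differs from it by a methoxy in place of the fluoro. In this assay compound 1 gives < 100000 nM, likewise a limit. The step that the two limits leave unreadable from compound 1 to compound 3 is therefore of no help, because of the limit of < 100000 nM in this assay, at which 2 of the 3 values shown sit. Compound 2 `CSc1ccc(C)cc1NCC1=NCCN1` carries a methylthio group instead; in this assay compound 2 gives 0.417 nM. Compound 4 `Cc1ccc(S(C)(=O)=O)c(NCC2=NCCN2)c1` differs from compound 3 by methyl in place of fluoro on an aromatic carbon. Among the measured compounds shown here, no measured step with a readable size bears on this change. Compound 4 is expected to stay close to compound 3, with an estimated step that the limit leaves unreadable from compound 3 to compound 4. Compound 4 is estimated at 50000 nM, between 3000 nM and 300000 nM.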

Compound 4, half-maximal effective concentration: 141 nM
The estimate for compound 4 lay 350-fold (2.55 log units) above the measured number, outside the stated range (below it).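

Of the three compounds with a methylsulfonyl group, compound 4 alone gives a number, so that group does not by itself send a value to the limit. With methyl at this position, methylsulfonyl in place of methylsulfanyl gives a 340-fold higher number from compound 2 to compound 4 (2.53 log units; beyond the scatter). The steps from compound 1 and from compound 3 to compound 4 cannot be read, because each starts from a limit of the assay: the limit of < 100000 nM in this assay, at which 2 of the 4 values shown sit.

The compounds shown leave open how far compound 1 and compound 3 truly lie from compound 4, and whether an ethyl group or an amine at this position would give a number.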